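The source may hold more compounds than are shown below. What is called first, only, known or untested is meant among the compounds shown, and "the series" means these compounds.

Three compounds have been measured in an assay on HEK293 cells for positive allosteric modulation of metabotropic glutamate receptor 2 (Rattus norvegicus), read by thallium flux; on this read-out lower numbers stand for smaller maximal responses and higher numbers for larger maximal responses:

Compound 1 `O=C(O)c1cc(-c2cccc(COc3ccc4c(c3)CN(CC3CC3)C4=O)c2)ccc1Cl` gives 85.7%.
Compound 2 `O=C(O)c1cc(-c2cccc(COc3ccc4c(c3)CN(Cc3ccc(C(F)(F)F)cc3)C4=O)c2)ccc1Cl` gives 86.7%.
Compound 3 `O=C(O)c1cc(-c2cccc(COc3ccc4c(c3)CN(C3CCC3)C4=O)c2)ccc1Cl` gives 90.3%.

Compound 3 stands highest of the three numbers, yet its gaps to the other two, a number 3.6 percentage points higher from compound 2 to compound 3 (within the scatter) and a number 4.6 percentage points higher from compound 1 to compound 3 (within the scatter), lie within the scatter, so no real order among them is shown. Compound 4 `CC(C)CCN1Cc2cc(OCc3cccc(-c4ccc(Cl)c(C(=O)O)c4)c3)ccc2C1=O` differs from compound 3 by isopentyl in place of cyclobutyl on an amide-type nitrogen in a ring. Every measured step concerns this same position: a number 1 percentage points higher from compound 1 to compound 2 (within the scatter) and the two steps already named were all within the scatter, so swapping groups here has left the maximal response essentially unchanged each time. The expected step of a number 2.3 percentage points lower from compound 3 to compound 4 (within the scatter) is therefore none beyond the scatter. Compound 4 is estimated to give 88%, with a range from 78% to 98%.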

Compound 4, largest response reached (Emax), in percent of the reference or control that the assay uses: 85.3%
Compound 4: the middle estimate sits 2.7 percentage points above what was measured, within the range that was stated.
By their numbers in this assay, from the lowest: compounds 4, 1, 2 and 3 (each within the scatter of the next).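

With isopentyl, an open chain with no ring now sits on the amide-type nitrogen, and in this assay the steps of a number 5 percentage points lower from compound 3 to compound 4 (within the scatter) and a number 1.4 percentage points lower from compound 2 to compound 4 (within the scatter) and a number 0.4 percentage points lower from compound 1 to compound 4 (within the scatter) show no real difference from the groups with rings. Among these four compounds, then, a ring in this group is not needed to keep the maximal response at this level. Nothing available explains why the response is so insensitive to this change.

Still open, on these data alone, is whether a group carrying an amine or a carboxylic acid at this nitrogen would leave the maximal response equally unchanged.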